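Amide side chain step, compound 2 to compound 3

The source may report more compounds than this note shows. Statements on the series, on what has been measured and on what is new or still open speak of the compounds shown alone.

In a functional assay on BXPC-3 cells (Homo sapiens) for antiproliferative activity, read by MTT assay, with a stated time of 24 h (on this read-out higher numbers stand for weaker inhibition and lower numbers for stronger inhibition), compound 1 `CCn1c(C(=O)NCC(=O)OC)ccc1C(CC)(CC)c1ccc(OCS(=O)(=O)c2ccccc2)c(C)c1` gives 20000 nM and compound 2 `CCn1c(C(=O)N[C@H](C)CO)ccc1C(CC)(CC)c1ccc(OCS(=O)(=O)c2ccccc2)c(C)c1` gives 10000 nM, so the two stand level within the scatter. Compound 3 `CCn1c(C(=O)N[C@H](CO)C(C)C)ccc1C(CC)(CC)c1ccc(OCS(=O)(=O)c2ccccc2)c(C)c1` carries 1-(hydroxymethyl)-2-methylpropyl in place of 1-(hydroxymethyl)ethyl on an amide-type nitrogen. Going by the values given here, the only measured step at this nitrogen, a 2.0-fold lower number from compound 1 to compound 2 (0.30 log units; within the scatter), stays within the scatter, and no measured step tests this exact change. No step beyond the scatter is therefore expected in this assay. The expected step is a 1.3-fold lower number from compound 2 to compound 3 (0.10 log units; within the scatter). For compound 3 the estimate is 8000 nM, with an expected range of 3000 nM to 20000 nM.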

Compound 3, half-maximal inhibitory concentration: 7720 nM
Estimate against measurement, compound 3: 1.0-fold (0.02 log units) above, within the range that was stated.
By their numbers in this assay, from the lowest: compounds 3, 2 and 1 (each within the scatter of the next, the first and the last beyond it).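

In this assay, 1-(hydroxymethyl)-2-methylpropyl in place of 1-(hydroxymethyl)ethyl on the amide-type nitrogen gives a 1.3-fold lower number from compound 2 to compound 3 (0.11 log units; within the scatter), so these two side chains stand level. Going by these compounds alone, in place of (methoxycarbonyl)methyl, the same group gives a 2.6-fold lower number from compound 1 to compound 3 (0.41 log units; beyond the scatter), the first step at this nitrogen beyond the scatter, and a modest one, with compound 2 within the scatter of both neighbours. Nothing measured explains either step.

On these data alone, whether a carboxylic acid, an amine or a longer chain on this nitrogen would move the number further stays open. As far as these compounds go, how a plain 2-methylpropyl group would compare with 1-(hydroxymethyl)-2-methylpropyl also stays open.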